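Dropping One Methoxy Group: What Compound 4 May Show

The compounds below may be only part of what the source reports. "The series", "measured", "known", "first", "only" and "open" are said of these compounds alone.

Compound 1 `COc1cc(-c2cc(/C=C/C(=O)c3ccc(N)cc3)[nH]n2)cc(OC)c1OC` gives 34900 nM in a functional assay on OVCAR-8 cells (Homo sapiens) for inhibition, read by sulforhodamine B assay, with a stated time of 48 h; on this read-out lower numbers stand for higher toxicity in this test and higher numbers for lower toxicity in this test.
Compound 2 `COc1ccc(C(=O)/C=C/c2cc(-c3cc(OC)c(OC)c(OC)c3)n[nH]2)cc1OC` gives 5640 nM in this assay.
Compound 3 `COc1ccc(C(=O)/C=C/c2cc(-c3cc(OC)c(OC)c(OC)c3)n[nH]2)cc1` gives only > 100000 nM in this assay, which is a limit of the test and not a number.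

Among these three, a 6.2-fold lower number from compound 1 to compound 2 (0.79 log units; beyond the scatter), and an at least 2.8-fold higher number from compound 1 to compound 3 (0.45 log units; beyond the scatter). The change of interest is hydrogen in place of methoxy on an aromatic carbon; it brought an at least 17-fold higher number from compound 2 to compound 3 (1.24 log units; beyond the scatter), with compound 3 sitting at the limit of > 100000 nM in this assay, at which 1 of the 3 values shown sits.

Compound 4 `COc1ccc(-c2cc(/C=C/C(=O)c3ccc(N)cc3)[nH]n2)cc1OC`, not yet measured, carries the same kind of change on compound 1: hydrogen in place of methoxy on an aromatic carbon. The two cores differ by 4-aminophenyl in place of 3,4-dimethoxyphenyl on a carbonyl carbon. The surroundings are not identical either: in compound 4 the spot is also meta to a methoxy group (2 heavy atoms), which the step from compound 2 to compound 3 does not share, so this is the same kind of change rather than the same change.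

Compound 4 is expected to show a 3.4-fold higher number from compound 1 to compound 4 (0.54 log units; beyond the scatter), resting on how compound 3 landed at the limit of > 100000 nM in this assay, at which 1 of the 3 values shown sits, after the same kind of change. Compound 4 is therefore estimated at 120000 nM, likely between 40000 nM and 400000 nM, quite possibly reported only as a limit.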

Compound 4, concentration lethal to 50% of the cells: 39000 nM
Compound 4: middle estimate off by 3.1-fold (0.49 log units), on the high side, outside the stated range (below it).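

In this assay, taking the methoxy group off the core of compound 1 leaves no readable change, with a 1.1-fold higher number from compound 1 to compound 4 (0.05 log units; within the scatter). Set beside the earlier pair, the same swap therefore does not carry over in size from one core to the other: the same change on two cores in this assay, an at least 17-fold higher number (1.24 log units; beyond the scatter) from compound 2 to compound 3 and a 1.1-fold higher number (0.05 log units; within the scatter) from compound 1 to compound 4, at least 15-fold (1.20 log units) apart, beyond the scatter of two such steps

Why the two pairs part is not shown, and the earlier step ends on compound 3, whose value is a limit and not a number: the limit of > 100000 nM in this assay, at which 1 of the 4 values shown sits.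

With only two pairs, the compounds shown leave open whether the swap would follow either of these patterns on a core bearing another group on the carbonyl carbon, such as a 4-hydroxyphenyl group. Also open, as far as these compounds go, is how a different replacement for the methoxy group would behave on these two cores, for example a fluorine atom or a longer chain such as ethoxy.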